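A few compounds are considered here, and "the series" means these few. Any claim that something is new, unique, unknown or untested is made for them only; others in the source may bear on it.

Compound 3, `COc1cc(OC)c(OC)cc1/C=C/C(=O)c1cc(O)ccc1O`, gives 2.1 ug/mL in a functional assay on cells (Erythrocyte, Rattus norvegicus) for inhibition, read by hemolysis, with a stated time of 1 h; on this read-out lower numbers stand for stronger inhibition and higher numbers for weaker inhibition. Compound 1, `COc1cc(OC)c(OC)cc1/C=C/C(=O)c1ccc(O)cc1`, gives 2.29 ug/mL, and compound 2, `COc1cc(OC)c(OC)cc1/C=C/C(=O)c1ccc([N+](=O)[O-])cc1`, gives 2.34 ug/mL; the three numbers sit close together, and both a 1.1-fold lower number from compound 1 to compound 3 (0.04 log units; within the scatter) and a 1.0-fold higher number from compound 1 to compound 2 (0.01 log units; within the scatter) fall within the scatter, so no one of them can be set apart. Compound 4, `COc1cc(OC)c(OC)cc1/C=C/C(=O)c1ccc(Cl)cc1`, has not yet been measured. It differs from compound 3 by 4-chlorophenyl in place of 2,5-dihydroxyphenyl on a carbonyl carbon. The step that bears most on this is the exchange of the group on the carbonyl carbon, a 1.1-fold lower number from compound 1 to compound 3 (0.04 log units; within the scatter), which did not move the number; the swap of hydroxy for nitro, a 1.0-fold higher number from compound 1 to compound 2 (0.01 log units; within the scatter), likewise left it unchanged. The step is therefore expected to be a 1.1-fold higher number from compound 3 to compound 4 (0.04 log units; within the scatter), nothing beyond the scatter. Compound 4 is estimated at 2.3 ug/mL, in a range from 1.2 ug/mL to 4.5 ug/mL.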

Compound 4, half-maximal inhibitory concentration: 2.3 ug/mL
The estimate for compound 4 equals the measured number at the digits printed; measured number inside the range.
By their numbers in this assay, from the lowest: compounds 3, 1, 4 and 2 (each within the scatter of the next).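

In this assay, chloro joins hydroxy and nitro on this aromatic carbon without any step beyond the scatter (a 1.0-fold higher number from compound 1 to compound 4 (0.00 log units; within the scatter); a 1.0-fold lower number from compound 2 to compound 4 (0.01 log units; within the scatter)). Exchanging 2,5-dihydroxyphenyl, with its hydrogen-bond donors, for 4-chlorophenyl, which has none, also stays within the scatter (a 1.1-fold higher number from compound 3 to compound 4 (0.04 log units; within the scatter)), so no exchange on the carbonyl carbon shown so far has moved the number. No measurement at hand explains this flat result. As far as these compounds go, whether an amine, a carboxylic acid or a longer chain on this aromatic carbon would move the number remains open, as does the effect of any change to the shared core.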